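A few compounds are considered here, and "the series" means these few. Any claim that something is new, unique, unknown or untested is made for them only; others in the source may bear on it.

The compounds here share one core and differ only at one end of the molecule. Compound 1 `COc1cc(Cn2cc(CNC(=O)c3ccc([N+](=O)[O-])o3)nn2)ccc1O` and compound 2 `COc1ccc(Cn2cc(CNC(=O)c3ccc([N+](=O)[O-])o3)nn2)cc1[N+](=O)[O-]` have both been tested in an ADME assay on MRC5 cells (Homo sapiens) for cytotoxicity; on this read-out lower numbers stand for stronger inhibition and higher numbers for weaker inhibition. In this assay compound 1 gives 182000 nM, and in this assay compound 2 gives 198000 nM; these two numbers lie within the usual scatter of each other, so nothing separates them. Compound 2 is thus one of two measured compounds whose numbers sit together at a weak level of inhibition.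

Compound 3 `O=C(NCc1cn(Cc2cccc([N+](=O)[O-])c2)nn1)c1ccc([N+](=O)[O-])o1` has not yet been measured in this assay. It differs from compound 2 in a single place: hydrogen in place of methoxy on an aromatic carbon

Because compound 1 gives 182000 nM and compound 2 gives 198000 nM in this assay, a change at this position has so far shown no step beyond the scatter, so no step beyond the scatter is expected for compound 3 either. The expected step of a 1.0-fold lower number from compound 2 to compound 3 (0.02 log units; within the scatter) is therefore small, with no clear direction. For compound 3 the estimate in this assay is 190000 nM, with a range from 95000 nM to 380000 nM.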

Compound 3, half-maximal inhibitory concentration: 199000 nM
Estimate against measurement, compound 3: 1.0-fold (0.02 log units) below; the range from low to high includes it.
By their numbers in this assay, from the lowest: compounds 1, 2 and 3 (each within the scatter of the next).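

In this assay, among these compounds, hydrogen in place of methoxy on an aromatic carbon, ortho to a nitro group, gives a 1.0-fold higher number from compound 2 to compound 3 (0.00 log units; within the scatter); this is the first direct look at that single group, and losing it leaves the number within the scatter. The wider exchange of 4-hydroxy-3-methoxyphenyl for 3-nitrophenyl gives a 1.1-fold higher number from compound 1 to compound 3 (0.04 log units; within the scatter), so even with more than one group on the six-membered ring differing, all three compounds remain together at the same weak level of inhibition. Nothing available explains why these numbers stay together.

On these data alone, what remains open is whether an amine or a carboxylic acid on this ring, or a longer chain in place of the saturated chain carbon bound to an aromatic nitrogen, would move the number beyond the scatter. All three compounds also keep the shared core, so these results cannot tell whether a change there would alter the number, and they say nothing about any read-out other than this one.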